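The source may hold more compounds than are shown below. What is called first, only, known or untested is meant among the compounds shown, and "the series" means these compounds.

Measured compounds in a functional assay on PC-3 cells (Homo sapiens) for inhibition, read by MTT assay, with a stated time of 72 h; on this read-out higher numbers stand for weaker inhibition and lower numbers for stronger inhibition:

- Compound 1, `C#CCSc1nc(Nc2ccccc2Cl)c2ccncc2n1`. Compound 1 gives > 80000 nM, which is a limit of this assay and not a number.
- Compound 2, `C#CCSc1nc(Nc2ccc(Cl)cc2Cl)c2ccncc2n1`. Compound 2 gives 30400 nM.
- Compound 3, `C#CCSc1nc(Nc2cc(OC)c(OC)c(OC)c2)c2ccncc2n1`. Compound 3 gives 30700 nM.

Compound 1 stands at the limit of > 80000 nM in this assay, at which 1 of the 3 values shown sits; where it lies beyond that limit is not known. Compound 2 and compound 3 give numbers that lie within the scatter of each other.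

For the measured compounds named here, the only step measured in one place is an at least 2.6-fold lower number from compound 1 to compound 2 (0.42 log units; beyond the scatter), an added chloro on the aryl amine.

Compound 4, `C#CCSc1nc(Nc2ccccc2O)c2ccncc2n1`, differs from compound 1 by hydroxy in place of chloro on an aromatic carbon. Going by the values given here, no measured pair trades a chloro for a hydroxy, so none of the measured steps bears directly on this change; the step from compound 1 to compound 2 only shows that a second chloro moved the number into the measurable range.

For compound 4 the expectation is therefore a number no higher from compound 1 to compound 4 (the limit leaves the size open), no step beyond the scatter, with a fair chance that only a limit is reported again.

The estimate for compound 4 in this assay is 80000 nM, with a range from 30000 nM to 200000 nM.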

Compound 4, half-maximal inhibitory concentration: 18700 nM
Compound 4: middle estimate off by 4.3-fold (0.63 log units), on the high side, outside the stated range (below it).
By their numbers in this assay, from the lowest: compounds 4, 2 and 3 (each within the scatter of the next). At a limit, above all of these: compound 1.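

In this assay, the change from 2-chlorophenyl to 2-hydroxyphenyl gives an at least 4.2-fold lower number from compound 1 to compound 4 (0.63 log units; beyond the scatter). The group ortho to a large group can therefore by itself bring this series to a measured number, with no second substituent on the aromatic ring, whereas the earlier step reached a measured number by adding a chloro and keeping the first. The true size of the step stays open, as compound 1 gives a limit and not a number: the limit of > 80000 nM in this assay, at which 1 of the 4 values shown sits.

Going by these compounds, it remains open whether the lower number follows from the hydroxy itself or only from the loss of the chloro, and an amine or a methoxy at this position would help to separate the two. On these data alone, it is also open whether the same exchange lowers the number with the second chloro of compound 2 in place.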